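A few compounds are considered here, and "the series" means these few. Any claim that something is new, unique, unknown or untested is made for them only; others in the source may bear on it.

Three compounds share a core in which the variable substituent sits on an aromatic carbon ortho to a ((4-methylphenyl)carbamoyl)amino group and para to a 2-carboxyphenyl group. Compound 1 `Cc1ccc(NC(=O)Nc2cc(-c3ccccc3C(=O)O)ccc2Oc2ccccc2C(C)(C)C)cc1` carries a 2-(tert-butyl)phenoxy group there, and in an assay on HeLa cells for inhibition of Indoleamine 2,3-dioxygenase 1 (Homo sapiens), with stated times of 1 h and 18 h (a higher number here means a weaker inhibitor, a lower number a stronger inhibitor), compound 1 gives 70 nM. Compound 2 `Cc1ccc(NC(=O)Nc2cc(-c3ccccc3C(=O)O)ccc2N(C)c2ccccc2C(C)(C)C)cc1` carries methyl(2-(tert-butyl)phenyl)amino instead; in this assay compound 2 reaches only the limit > 1000 nM, which is a limit of the assay (the limit of > 1000 nM in this assay, at which 1 of the 3 values shown sits), and the step is an at least 14-fold higher number from compound 1 to compound 2 (1.15 log units; beyond the scatter). Compound 3 `Cc1ccc(NC(=O)Nc2cc(-c3ccccc3C(=O)O)ccc2N2CCC[C@@H]3CCCC[C@@H]32)cc1` carries a saturated bicyclic amine, and in this assay compound 3 gives 159 nM, which is a 2.3-fold higher number from compound 1 to compound 3 (0.36 log units; beyond the scatter) and an at least 6.2-fold lower number from compound 2 to compound 3 (0.79 log units; beyond the scatter). Compound 3 therefore holds the highest of the two numbers shown, with compound 1 nearest.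

Compound 4 `Cc1ccc(NC(=O)Nc2cc(-c3ccccc3C(=O)O)ccc2N(CC(C)C)CC(C)C)cc1` differs from compound 3 by a group of 9 heavy atoms (8 carbon, 1 nitrogen; no ring) in place of a group of 10 heavy atoms (9 carbon, 1 nitrogen; one six-membered non-aromatic ring of carbon only, one six-membered non-aromatic ring with 1 hetero atom), on an aromatic carbon. The nitrogen-linked substituent stays, its two rings are opened. The measured steps that bear on this are a 2.3-fold higher number from compound 1 to compound 3 (0.36 log units; beyond the scatter) and an at least 6.2-fold lower number from compound 2 to compound 3 (0.79 log units; beyond the scatter): a nitrogen-linked group has so far given the highest number and the limit. A step of modest size, toward a higher number, is expected. Compound 4 is expected to give about 320 nM in this assay, between 110 nM and 1000 nM. This amounts to an expected 2.0-fold higher number from compound 3 to compound 4 (0.30 log units; within the scatter).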

Compound 4, half-maximal inhibitory concentration: 13 nM
Estimate against measurement, compound 4: 25-fold (1.39 log units) above; measured number outside the range, below it.
By their numbers in this assay, from the lowest: compound 4; then compound 1; then compound 3. At a limit, above all of these: compound 2.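

The change to diisobutylamino shows that a nitrogen-linked group at this position need not raise the number in this assay: opening both rings of the saturated bicyclic amine gives a 12-fold lower number from compound 3 to compound 4 (1.09 log units; beyond the scatter), and the same group also improves on the 2-(tert-butyl)phenoxy group, with a 5.4-fold lower number from compound 1 to compound 4 (0.73 log units; beyond the scatter). Compound 2 gives only a limit, so the change from its methyl(2-(tert-butyl)phenyl)amino group to diisobutylamino, an at least 76-fold lower number from compound 2 to compound 4 (1.88 log units; beyond the scatter), is a bound and not a measured size: the limit of > 1000 nM in this assay, at which 1 of the 4 values shown sits. With compound 4 now the strongest inhibitor of the four, and nitrogen-linked groups at both the lowest number and the limit, the linking atom alone does not set the result; what the nitrogen carries matters as well.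

The compounds shown leave open how far this result depends on the isobutyl chains, since a shorter chain as in diethylamino, a longer chain as in dipentylamino, or a single ring such as piperidine would each test a different part of the change. They also leave open whether an oxygen-linked isobutoxy group would behave as diisobutylamino does, and they give no cause for the gain.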